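Fluorophenyl position swap in a cytotoxicity series

The source may hold more compounds than are shown below. What is called first, only, known or untested is meant among the compounds shown, and "the series" means these compounds.

The three measured compounds share a central ring bearing two double-bonded chain carbons, each carrying an aryl group. Compound 1 `COc1cc(/C=C2\CN(C)C/C(=C\c3ccccc3F)C2=O)cc(OC)c1OC` gives 12100 nM in an ADME assay on L02 cells (Homo sapiens) for cytotoxicity, read by MTT assay, with a stated time of 24 h; a higher number here means a weaker inhibitor, a lower number a stronger inhibitor. Compound 3 `COc1cc(/C=C2\CN(C)C/C(=C\c3ccc(F)cc3)C2=O)cc(OC)c1OC` differs from compound 1 in one place. In this assay compound 3 gives 10700 nM; the difference between the two is 4-fluorophenyl in place of 2-fluorophenyl on a double-bonded chain carbon bound to a double-bonded ring carbon, and the step is a 1.1-fold lower number from compound 1 to compound 3 (0.05 log units; within the scatter). Compound 2 `CN1C/C(=C\c2ccc(C#N)cc2)C(=O)/C(=C/c2ccccc2F)C1` gives 11000 nM in this assay; its values sit within the scatter of both compound 1 and compound 3, so no ordering among the three is claimed. The difference between the core of compound 2 and the core of compound 1 is not broken down here.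

Compound 4 `CN1C/C(=C\c2ccc(F)cc2)C(=O)/C(=C/c2ccc(C#N)cc2)C1` has not yet been measured. It differs from compound 2 by 4-fluorophenyl in place of 2-fluorophenyl on a double-bonded chain carbon bound to a double-bonded ring carbon, which is the same change as that from compound 1 to compound 3, made at the same place. On the strength of that earlier step a 1.1-fold lower number from compound 1 to compound 3 (0.05 log units; within the scatter) being within the scatter, the step from compound 2 to compound 4 is expected to be small, a 1.0-fold lower number from compound 2 to compound 4 (0.02 log units; within the scatter), and to stay within the scatter as well. Compound 4 is therefore estimated to give 10500 nM in this assay, with a likely range from 5500 nM to 21000 nM.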

Compound 4, half-maximal inhibitory concentration: 20900 nM
For compound 4 the middle estimate is 2.0-fold (0.30 log units) below the measured one; low and high end bracket the measured number.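

In this assay, the change from 2-fluorophenyl to 4-fluorophenyl on a double-bonded chain carbon bound to a double-bonded ring carbon has now been read on a second core, and the step is a 1.9-fold higher number from compound 2 to compound 4 (0.28 log units; within the scatter). Set beside the same change on the core of compound 1, the two steps cannot be told apart: the same change on two cores in this assay, a 1.1-fold lower number (0.05 log units; within the scatter) from compound 1 to compound 3 and a 1.9-fold higher number (0.28 log units; within the scatter) from compound 2 to compound 4, 2.1-fold (0.33 log units) apart, within the scatter of two such steps

This shows that, on both cores, the change stays within the usual scatter of repeated measurements, and these two pairs give no sound basis for claiming that the core alters its size. It does not show that the two steps are equal or that the change is without effect on either core, and two pairs cannot establish a rule for other cores in the series.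

The compounds shown leave open whether the same change stays this small when the other aryl group carries an amine or a carboxylic acid instead of the nitrile or the methoxy groups. They also leave open whether a group other than fluorine, such as chlorine or a hydroxyl group, would give a step beyond the scatter in this assay.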